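The compounds below may be only part of what the source reports. "The series", "measured", "known", "first", "only" and "open" are said of these compounds alone.

Compounds measured so far:

compound 1, `O=S(=O)(Nc1ccccc1Cl)c1ccc(-c2cnc(C3CC3)o2)cc1` — 429 nM
compound 2, `Cc1ccc(NS(=O)(=O)c2ccc(-c3cnc(C4CC4)o3)cc2)cc1C` — 420 nM
compound 3, `Cc1ccc(Cl)c(NS(=O)(=O)c2ccc(-c3cnc(C4CC4)o3)cc2)c1` — 48.8 nM

All three share one core and differ only in the aryl group on the sulfonamide nitrogen. In a functional assay on cells (leukaemia cell line, Homo sapiens) for inhibition, read by sulforhodamine B assay, with a stated time of 48 h (a lower number here means a stronger inhibitor of growth, a higher number a weaker inhibitor of growth), compound 2 gives 420 nM, the second highest of the three numbers. Its nearest neighbour is compound 1: the step of a 1.0-fold lower number from compound 1 to compound 2 (0.01 log units; within the scatter) lies within the scatter, so the two are not distinguished. Its furthest neighbour is compound 3, reached by an 8.6-fold lower number from compound 2 to compound 3 (0.93 log units; beyond the scatter), a modest gain. The same gain is seen from compound 1 by an 8.8-fold lower number from compound 1 to compound 3 (0.94 log units; beyond the scatter).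

Compound 4, `Cc1cc(Cl)cc(NS(=O)(=O)c2ccc(-c3cnc(C4CC4)o3)cc2)c1`, is the next candidate. Relative to compound 2 the change is 3-chloro-5-methylphenyl in place of 3,4-dimethylphenyl on a sulfonamide nitrogen. Within the data shown here, both bearing steps, an 8.6-fold lower number from compound 2 to compound 3 (0.93 log units; beyond the scatter) and an 8.8-fold lower number from compound 1 to compound 3 (0.94 log units; beyond the scatter), show that a chlorine-and-methyl aryl group can give a modest lower number than a dimethyl or plain chloro aryl; but compound 4 carries its chlorine and methyl in a different arrangement from compound 3, and no measured pair tests that arrangement. The expectation is therefore a step in the lowering direction but smaller than that to compound 3, with wide uncertainty. In this assay compound 4 is expected to give about 200 nM, within 50 nM to 800 nM; this estimate corresponds to a 2.1-fold lower number from compound 2 to compound 4 (0.32 log units; beyond the scatter).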

Compound 4, concentration for 50% growth inhibition: 175 nM
The estimate for compound 4 lay 1.1-fold (0.06 log units) above the measured number; the measured number falls inside the stated range.
By their numbers in this assay, from the lowest: compound 3; then compound 4; then compounds 2 and 1 (each within the scatter of the next).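

In this assay the aryl group on a sulfonamide nitrogen now shows that compound 3 is not the only chlorine-and-methyl arrangement to improve on the earlier aryl groups: 3-chloro-5-methylphenyl in place of 3,4-dimethylphenyl gives a 2.4-fold lower number from compound 2 to compound 4 (0.38 log units; beyond the scatter) and the same group in place of 2-chlorophenyl gives a 2.5-fold lower number from compound 1 to compound 4 (0.39 log units; beyond the scatter) as a matching modest step. Among these compounds, the arrangement of the two substituents also counts, which the earlier compounds could not show: with the same chlorine and methyl on the ring, the change to 3-chloro-5-methylphenyl gives a 3.6-fold higher number from compound 3 to compound 4 (0.55 log units; beyond the scatter) and leaves compound 3 with the lowest number of the four. Nothing available here bears on what lies behind these differences.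

Still open, on these data alone, is how the number moves when the chlorine or the methyl on this aryl group gives way to a methoxy group, an amine or a carboxylic acid. Also open, as far as these compounds go, is whether the order of the chlorine-and-methyl arrangements holds with a bromine or a trifluoromethyl group in place of the chlorine.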